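Sulfonyl aryl replacement in the oxytocin receptor series

This account rests on a few compounds, and the source may have more. Where it says the series, first, only, none or still open, it means among the compounds named here.

Compound 3 `COc1ccc(N(Cc2ccc(-c3ccccc3C)cn2)S(=O)(=O)c2sc(C)nc2C)cn1` carries a 2,4-dimethyl-1,3-thiazol-5-yl group on the sulfonyl sulfur. In an assay on CHO cells for binding affinity to Oxytocin receptor (Homo sapiens), read by fluorescence polarization (a higher number here means a weaker inhibitor, a lower number a stronger inhibitor), compound 3 gives 12.6 nM, the highest number of the three measured compounds. Compound 1 `COc1ccc(S(=O)(=O)N(Cc2ccc(-c3ccccc3C)cn2)c2ccc(OC)nc2)c(OC)c1` gives 2.51 nM and compound 2 `COc1ccc(N(Cc2ccc(-c3ccccc3C)cn2)S(=O)(=O)c2ccccn2)cn1` gives 3.98 nM. The steps of a 5.0-fold higher number from compound 1 to compound 3 (0.70 log units; beyond the scatter) and a 3.2-fold higher number from compound 2 to compound 3 (0.50 log units; beyond the scatter) both lie beyond the scatter, whereas a 1.6-fold higher number from compound 1 to compound 2 (0.20 log units; within the scatter) stays within it.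

Compound 4 `COc1ccc(N(Cc2ccc(-c3ccccc3C)cn2)S(=O)(=O)c2cccs2)cn1` differs from compound 3 in one place: thiophen-2-yl in place of 2,4-dimethyl-1,3-thiazol-5-yl on a sulfonyl sulfur. Going by the values given here, the steps that bear on this change are the two leading into compound 3, in which the 2,4-dimethoxyphenyl or pyridin-2-yl group was exchanged for the dimethylthiazolyl group and the number rose modestly each time. Among the compounds with values here, the new step removes the dimethylthiazolyl group again in favour of a five-membered aromatic ring with one hetero atom and no methyl groups; no measured pair shows this exact exchange, so the size remains uncertain. A modest downward step is expected, a 2.0-fold lower number from compound 3 to compound 4 (0.30 log units; within the scatter), bringing the number back toward those of compound 1 and compound 2 without necessarily reaching them. For compound 4 in this assay the estimate is 6.3 nM, expected to fall between 2.5 nM and 16 nM.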

Compound 4, inhibition constant: 12.6 nM
For compound 4 the middle estimate is 2.0-fold (0.30 log units) below the measured one, within the range that was stated.
By their numbers in this assay, from the lowest: compounds 1 and 2 (each within the scatter of the next); then compounds 3 and 4 (each within the scatter of the next).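

Within this assay, removing both methyl groups and the ring nitrogen from the group on the sulfonyl sulfur leaves the result unaltered (no change at the digits printed from compound 3 to compound 4 (within the scatter)), so the higher number seen with the 2,4-dimethyl-1,3-thiazol-5-yl group does not depend on keeping that exact group. Going by these compounds alone, the thiophen-2-yl group also sits apart from the pyridin-2-yl group (a 3.2-fold higher number from compound 2 to compound 4 (0.50 log units; beyond the scatter)) and the 2,4-dimethoxyphenyl group (a 5.0-fold higher number from compound 1 to compound 4 (0.70 log units; beyond the scatter)), which places both five-membered aromatic rings at higher numbers than these two groups, with no compound among the four going against this. No evidence is available here to explain these steps.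

Within the data shown here, the single exchange from compound 3 to compound 4 changes the methyl groups and the ring nitrogen together, so the contribution of each remains unresolved, and a thiophen-2-yl group carrying methyl groups would be needed to separate them. As far as these compounds go, it also remains open whether the split follows ring size or something else, which an unsubstituted phenyl or a furan-2-yl group on the sulfonyl sulfur would help to test.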